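This account rests on a few compounds, and the source may have more. Where it says the series, first, only, none or still open, it means among the compounds named here.

Measured in a functional assay on HUVEC cells (Homo sapiens) for inhibition, tested at 10 ug/mL; a lower number here means a weaker effect, a higher number a stronger effect of the compound at the concentration tested:
compound 1 `COc1cc(/C=C/C(=O)c2cccc(NC(=O)c3ccc(Cl)cc3)c2)ccc1O`, 66%
compound 2 `COc1cc(/C=C/C(=O)c2cccc(NC(=O)c3ccc(Cl)cc3Cl)c2)ccc1O`, 70%
compound 3 `COc1cc(/C=C/C(=O)c2cccc(NC(=O)c3ccc(Cl)c(Cl)c3)c2)ccc1O`, 45%

Compound 1 sits together with compound 2: a number 4 percentage points higher from compound 1 to compound 2 (within the scatter). Compound 3 sits clearly below compound 1: a number 21 percentage points lower from compound 1 to compound 3 (beyond the scatter). The two dichlorophenyl compounds separate in the same way: a number 25 percentage points lower from compound 2 to compound 3 (beyond the scatter). All three measured compounds carry a chlorinated phenyl on the amide carbonyl, and every measured step concerns only how many chlorines that ring carries and where they stand.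

Compound 4 `COc1cc(/C=C/C(=O)c2cccc(NC(=O)C(C)C)c2)ccc1O` has not been measured. Set against compound 1, (isopropyl in place of 4-chlorophenyl on a carbonyl carbon). Among the measured compounds shown here, no measured step removes the aromatic ring from the amide carbonyl, so none of the three steps bears directly on this change. They show only that adding a chloro to compound 1 can leave the number within the scatter or lower it modestly. For the measured compounds named here, the step to compound 4 is expected to be small to modest and downward rather than upward, because a number 21 percentage points lower from compound 1 to compound 3 (beyond the scatter) is the only step beyond the scatter and it runs downward. For compound 4 the expected step is a number 11 percentage points lower from compound 1 to compound 4 (beyond the scatter). Compound 4 is estimated at 55% in this assay, with a range from 35% to 75%.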

Compound 4, a percentage reported as inhibition, at one concentration (the size of the read-out at that concentration, not a potency): 56%
Estimate against measurement, compound 4: 1 percentage points below; low and high end bracket the measured number.
By their numbers in this assay, from the lowest: compound 3; then compounds 4, 1 and 2 (each within the scatter of the next, the first and the last beyond it).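

In this assay this is the first change at the amide carbonyl that removes the aromatic ring rather than moving or adding a chlorine, and isopropyl in place of 4-chlorophenyl on a carbonyl carbon stays within the scatter (a number 10 percentage points lower from compound 1 to compound 4 (within the scatter)), so among these compounds a chlorinated phenyl is not needed at this position for a read-out of this size. The same exchange does not run one way across the series: it lies beyond the scatter in opposite directions against the two dichlorophenyl compounds (a number 11 percentage points higher from compound 3 to compound 4 (beyond the scatter); a number 14 percentage points lower from compound 2 to compound 4 (beyond the scatter)), so its outcome depends on which chlorinated ring leaves, and the small isopropyl group separates the 2,4-dichlorophenyl and 3,4-dichlorophenyl compounds without matching either. No supporting data are available to explain these steps.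

Open, as far as these compounds go, is what a plain phenyl on the carbonyl carbon would give, which would separate the part played by the ring from that of the chlorine. Also open, from the compounds shown here alone, is how a cyclohexyl, a longer alkyl chain, an amine or a carboxylic acid at this position would read out, and whether any of these steps would hold at other concentrations.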